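A Nitro Group Enters the Fused Ring of Compound 1

This account rests on a few compounds, and the source may have more. Where it says the series, first, only, none or still open, it means among the compounds named here.

Compound 1, `Nc1ccccc1NC(=O)c1ccc(CSC(=S)N2CCc3ccccc32)cc1`: 38%
Compound 2, `CN(Cc1cccnc1)C(=S)SCc1ccc(C(=O)Nc2ccccc2N)cc1`: 16.4%

Of the compounds shown here, two have been measured in a functional assay on HeLa cells (Homo sapiens) for antiproliferative activity, read by CCK-8 assay, with a stated time of 72 h, tested at 2 uM; on this read-out lower numbers stand for a weaker effect and higher numbers for a stronger effect at the one concentration tested. Compound 1 gives 38%, the higher of the two numbers; compound 2 gives 16.4%. For the measured compounds named here, the only measured step, a number 21.6 percentage points lower from compound 1 to compound 2 (beyond the scatter), puts methyl((pyridin-3-yl)methyl)amino in place of 2,3-dihydro-1H-indol-1-yl on a thiocarbonyl carbon, so it exchanges the whole group on the thiocarbonyl carbon.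

Compound 3, `Nc1ccccc1NC(=O)c1ccc(CSC(=S)N2CCc3ccc([N+](=O)[O-])cc32)cc1`, has not yet been measured. It keeps the group of compound 1 and differs from it only by nitro in place of hydrogen on an aromatic carbon. Going by the values given here, no measured step touches this part of the structure, so nothing in the data speaks for a change in either direction. The expectation is therefore a step of about no change at the digits printed from compound 1 to compound 3 (within the scatter), that is, a number close to that of compound 1 and not beyond the scatter. The estimate for compound 3 in this assay is 38%, with a range from 20% to 58%.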

Compound 3, a percentage reported as inhibition, at one concentration (the size of the read-out at that concentration, not a potency): 45.7%
Compound 3: the middle estimate sits 7.7 percentage points below what was measured; low and high end bracket the measured number.
By their numbers in this assay, from the lowest: compound 2; then compounds 1 and 3 (each within the scatter of the next).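

For the compounds shown here, this is the first measured change on the ring system of compound 1 itself, since the earlier step exchanged the whole group on the thiocarbonyl carbon. In this assay, putting nitro in place of hydrogen gives a number 7.7 percentage points higher from compound 1 to compound 3 (within the scatter), so the two compounds cannot be told apart on this read-out. An aromatic carbon that is meta to a fused ring and para to a fused ring can therefore carry a group of 3 heavy atoms without a change beyond the scatter, and no further data are available to explain this result.

As far as these compounds go, whether an amine or a chlorine atom on this same aromatic carbon would also stay within the scatter of compound 1 remains open, as does the outcome of placing nitro on a different carbon of that ring. From the compounds shown here alone, each compound also has a number at only one concentration, which gives the size of the effect there and not a potency, so whether compound 1 and compound 3 would separate at other concentrations is still unknown.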